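The source may hold more compounds than are shown below. What is called first, only, known or untested is meant among the compounds shown, and "the series" means these compounds.

Measured compounds:
- compound 1 `O=c1nc(N2CCN(CC3CCCCC3)CC2)sc2c([N+](=O)[O-])cc(C(F)(F)F)cc12`: in an ADME assay on Vero cells (Chlorocebus sabaeus) for cytotoxicity, read by MTT assay, with a stated time of 72 h (a higher number here means that more compound is tolerated, a lower number that less compound is tolerated), compound 1 gives > 125000 nM, a limit of the assay.
- compound 2 `CCC(C)C(=O)N1CCN(c2nc(=O)c3cc(C(F)(F)F)cc([N+](=O)[O-])c3s2)CC1`: in this assay compound 2 gives > 125000 nM, also a limit.
- compound 3 `O=C(C1CCC1)N1CCN(c2nc(=O)c3cc(C(F)(F)F)cc([N+](=O)[O-])c3s2)CC1`: in this assay compound 3 gives > 125000 nM, again a limit.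

Compound 1 stands only at a limit in this assay, and the two further values shown are limits as well; all three sit at the limit of > 125000 nM in this assay, at which 3 of the 3 values shown sit. The unmeasured compound 4 `CC(C)(C)C1CCC(C(=O)N2CCN(c3nc(=O)c4cc(C(F)(F)F)cc([N+](=O)[O-])c4s3)CC2)CC1` differs from compound 1 by (4-(tert-butyl)cyclohexyl)carbonyl in place of cyclohexylmethyl on an amine nitrogen in a ring. Within the data shown here, the steps that bear on this change are those at the same ring nitrogen, a step that the two limits leave unreadable from compound 1 to compound 2 and a step that the two limits leave unreadable from compound 1 to compound 3, together with a step that the two limits leave unreadable from compound 2 to compound 3 on the carbonyl carbon; their sizes cannot be read because the limit of > 125000 nM in this assay, at which 3 of the 3 values shown sit, holds at both ends of each. Nothing measured therefore points to a step beyond the scatter in either direction, and no step beyond the scatter is expected in this assay. The estimate for compound 4 in this assay is 125000 nM, with a range from 60000 nM to 250000 nM, most likely reported again only as a limit. The expected step is therefore a number no higher from compound 1 to compound 4 (the limit leaves the size open), within the scatter.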

Compound 4, half-maximal cytotoxic concentration: > 125000 nM
Compound 4: no number, only a limit (the forecaster's own chance of this, stated with the estimate: 85%); the middle value lies on the limit itself.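

In this assay compound 4 gives > 125000 nM, a limit. No step among compound 1, compound 2, compound 3 and compound 4 can be read, because all four stand at the same limit: the limit of > 125000 nM in this assay, at which 4 of the 4 values shown sit.

The compounds shown leave open at what concentration any of them becomes cytotoxic, and whether the changes on the ring nitrogen alter that concentration.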